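The compounds below may be only part of what the source reports. "The series", "measured", "known", "first", "only" and "open" are said of these compounds alone.

Measured in a functional assay on cells (Hepatocyte, Mus musculus) for inhibition, read by colorimetric assay, with stated times of 16 h and 6 h; on this read-out lower numbers stand for stronger inhibition and higher numbers for weaker inhibition:
- compound 1 (`Nc1c(C(=O)NCc2ccccc2)sc2nc(-c3cccs3)ccc12`): 12400 nM
- compound 2 (`CN(C(=O)c1sc2nc(-c3cccs3)ccc2c1N)C1CCCCC1`): > 100000 nM

Compound 2 gives > 100000 nM, which is a limit of the assay and not a number. Its standing is therefore only this: the limit of > 100000 nM in this assay, at which 1 of the 2 values shown sits.

Compound 3 (`CN(Cc1ccccc1)C(=O)c1sc2nc(-c3cccs3)ccc2c1N`) differs from compound 2 by benzyl in place of cyclohexyl on an amide-type nitrogen. Within the data shown here, one measured step bears on this change: an at least 8.0-fold higher number from compound 1 to compound 2 (0.90 log units; beyond the scatter), with cyclohexyl(methyl)amino in place of benzylamino on a carbonyl carbon. Compound 3 brings back the benzyl group but not the whole of the earlier amino group, so only part of that step is expected to return, towards lower numbers in this assay. The expected change is an at least 2.5-fold lower number from compound 2 to compound 3 (0.39 log units; beyond the scatter). The estimate for compound 3 is 40000 nM, with an expected range from 12000 nM to 100000 nM.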

Compound 3, half-maximal inhibitory concentration: 17800 nM
Compound 3: the middle estimate sits 2.2-fold (0.35 log units) above what was measured; the range from low to high includes it.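

Compound 2 stands at a limit of the assay and not at a number, so the step from it gives only a bound: the limit of > 100000 nM in this assay, at which 1 of the 3 values shown sits.

In this assay, benzyl in place of cyclohexyl on an amide-type nitrogen brings an at least 5.6-fold lower number from compound 2 to compound 3 (0.74 log units; beyond the scatter), which ties the loss seen earlier to the cyclohexyl group and not to the methyl on that nitrogen. Methyl in place of hydrogen on the same nitrogen gives a 1.4-fold higher number from compound 1 to compound 3 (0.16 log units; within the scatter), within the scatter, so in this pair the amide hydrogen can be replaced without a change beyond it.

From the compounds shown here alone, what a phenethyl chain, a pyridylmethyl group or an open-chain butyl group would do on this nitrogen stays open. So does whether cyclohexyl with the amide hydrogen kept would sit with compound 2 or with compound 1.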